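Swapping trifluoromethyl for tert-butoxy on a pyrimidine ring

The source may hold more compounds than are shown below. What is called first, only, known or untested is meant among the compounds shown, and "the series" means these compounds.

Measured so far:
compound 1 `N#Cc1cnc(NCc2cnccc2C(F)(F)F)cc1N[C@H]1CC[C@@H](O)CC1`, 100 nM
compound 2 `N#Cc1cnc(NCc2cncnc2C(F)(F)F)cc1N[C@H]1CC[C@@H](O)CC1`, 450 nM

In an assay on isolated protein for inhibition of protein kinase C theta type (Homo sapiens), read by TR-FRET, with a stated time of 2 h (a lower number here means a stronger inhibitor, a higher number a weaker inhibitor), compound 2 gives the higher of the two numbers, and compound 1 gives 100 nM, a gap that lies beyond the scatter. Compound 3 `CC(C)(C)Oc1ncncc1CNc1cc(N[C@H]2CC[C@@H](O)CC2)c(C#N)cn1` is not yet measured. It differs from compound 2 by tert-butoxy in place of trifluoromethyl on an aromatic carbon. For the measured compounds named here, no measured pair shows this change, so its effect is unknown. From compound 2 to compound 3 a modest step of a 1.5-fold lower number from compound 2 to compound 3 (0.18 log units; within the scatter) is expected, possibly toward a lower number, but likely within the scatter. Compound 3 is estimated at 300 nM, between 80 nM and 1200 nM.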

Compound 3, half-maximal inhibitory concentration: 200 nM
Compound 3: middle estimate off by 1.5-fold (0.18 log units), on the high side; the measured number falls inside the stated range.
By their numbers in this assay, from the lowest: compounds 1 and 3 (each within the scatter of the next); then compound 2.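

In this assay, tert-butoxy in place of trifluoromethyl on this aromatic carbon gives a 2.3-fold lower number from compound 2 to compound 3 (0.35 log units; beyond the scatter), a modest step beyond the scatter. This carbon, next to the ring nitrogen, can therefore carry tert-butoxy, which brings a hydrogen-bond acceptor that trifluoromethyl lacks, with no loss of inhibition. No available evidence explains the step. On these data alone, whether the oxygen or the carbons of tert-butoxy matter stays open, and methoxy or a plain tert-butyl group on this carbon would separate the two. Also open, as far as these compounds go, is whether the same swap on compound 1 would give a similar step.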